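The source may hold more compounds than are shown below. What is called first, only, known or untested is meant among the compounds shown, and "the series" means these compounds.

Of the compounds shown here, three of a shared core have been measured in a functional assay on B16-F10 cells (Mus musculus) for antiproliferative activity, read by MTT assay, with a stated time of 48 h; a higher number here means a weaker inhibitor, a lower number a stronger inhibitor. Compound 1 `CCCCCCCCCCCCOc1ccc(C(=O)/C=C/c2c(/C=C/c3ccc(OC)cc3)cc(OC)cc2OC)cc1` gives 12.7 ug/mL; compound 2 `COc1ccc(/C=C/c2cc(OC)cc(OC)c2/C=C/C(=O)c2cccc(OC)c2)cc1` gives 4.3 ug/mL; compound 3 `COc1ccc(/C=C/c2cc(OC)cc(OC)c2/C=C/C(=O)c2ccc(C)cc2)cc1` gives 5.3 ug/mL. Among the compounds with values here, the one single-point step among them, a 1.2-fold higher number from compound 2 to compound 3 (0.09 log units; within the scatter), is a replacement on the aryl ring attached to the carbonyl and lies within the scatter. Compound 3 therefore stands second highest of the three numbers, with compound 2 nearest and within the scatter, and compound 1 furthest, its number beyond the scatter above that of compound 3.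

Compound 4 `CCCCCCOc1ccc(C(=O)/C=C/c2c(/C=C/c3ccc(OC)cc3)cc(OC)cc2OC)cc1` differs from compound 3 by hexyloxy in place of methyl on an aromatic carbon. Within the data shown here, no measured step reproduces this exchange directly. The step of a 1.2-fold higher number from compound 2 to compound 3 (0.09 log units; within the scatter) shows that a small change on this aryl ring barely moves the number. Compound 1 carries a dodecyloxy group at the same place where compound 4 carries hexyloxy, and compound 1 sits highest of the three values, while compound 3 with its methyl sits lower; the hexyloxy chain of compound 4 lies between those two. The account therefore expects a modest rise in the number from compound 3 to compound 4, a 1.5-fold higher number from compound 3 to compound 4 (0.18 log units; within the scatter), partly beyond the scatter. Compound 4 is estimated at 8 ug/mL, within a range of 4 ug/mL to 16 ug/mL.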

Compound 4, half-maximal inhibitory concentration: 10.4 ug/mL
The estimate for compound 4 lay 1.3-fold (0.11 log units) below the measured number; the range from low to high includes it.
By their numbers in this assay, from the lowest: compounds 2, 3, 4 and 1 (each within the scatter of the next, the first and the last beyond it).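

In this assay, hexyloxy in place of methyl on this aromatic carbon gives a 2.0-fold higher number from compound 3 to compound 4 (0.29 log units; within the scatter), so a chain carrying an oxygen can replace the small methyl group without a step that leaves the scatter. Hexyloxy also stands close to the longer dodecyloxy chain at the same place, with a 1.2-fold lower number from compound 1 to compound 4 (0.09 log units; within the scatter), which puts compound 4 within the scatter of both neighbours even though compound 3 at 5.3 ug/mL and compound 1 at 12.7 ug/mL are beyond the scatter of each other: the two single steps are each too small to read, and only the ends of this short series are separated. Nothing shown here offers a reason for these numbers.

The compounds shown leave open where along the series the numbers part, which an octyloxy or decyloxy chain at this aromatic carbon would help to settle. They also leave open how a hydroxy group, an amine or a carboxylic acid at the same place would compare with methyl and hexyloxy.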